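This account rests on a few compounds, and the source may have more. Where it says the series, first, only, none or still open, it means among the compounds named here.

Compound 1 `COc1ccc(SCc2ccc(C(=O)Nc3ccccc3N)cc2)cc1` gives > 32000 nM, which is a limit of the assay. Compound 2 `CCc1ccc(SCc2ccc(C(=O)Nc3ccccc3N)cc2)cc1` gives > 32000 nM, also a limit. Compound 3 `Nc1ccccc1NC(=O)c1ccc(CSc2nccc(C(F)(F)F)n2)cc1` gives > 32000 nM, again a limit.

These values come from an assay on isolated protein for inhibition of histone deacetylase 8 (Homo sapiens), read by fluorescence, with stated times of 10 min and 30 min; a higher number here means a weaker inhibitor, a lower number a stronger inhibitor. Among the measured compounds shown here, no measured compound has a number here; each sits at a limit: the limit of > 32000 nM in this assay, at which 3 of the 3 values shown sit. Compound 2 therefore stands nowhere in particular among the values shown. Its value in this assay is a limit, the two others are limits as well, and so the three compounds cannot be ranked against one another. For the measured compounds named here, the only single-point step among them, a step that the two limits leave unreadable from compound 1 to compound 2, is unreadable for the same reason.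

Compound 4 `Cc1cc(C)cc(SCc2ccc(C(=O)Nc3ccccc3N)cc2)c1` has not yet been measured. It differs from compound 2 in one place: 3,5-dimethylphenyl in place of 4-ethylphenyl on a sulfur. The step that bears on this change is a step that the two limits leave unreadable from compound 1 to compound 2, a change on an aromatic carbon of the same group, and it gives no size to work from, since both ends are limits. With every measured value a limit, the expectation for compound 4 is that the step that the limit leaves unreadable from compound 2 to compound 4 will again be unreadable and that this assay will most likely report a limit once more. The estimate for compound 4 is accordingly 50000 nM, with a range from 20000 nM to 200000 nM.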

Compound 4, half-maximal inhibitory concentration: > 32000 nM
Compound 4 was reported as a limit; the forecaster's own chance of this, stated with the estimate: 85%; the middle value lies beyond the limit too.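

In this assay compound 4 gives > 32000 nM, again a limit. Its steps from compound 1 and from compound 2 cannot be read, so no size of change can be stated. The compounds shown leave open how strongly any of them inhibits the enzyme, and whether any group on the sulfur would give a measurable value: the limit of > 32000 nM in this assay, at which 4 of the 4 values shown sit.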